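A few compounds are considered here, and "the series" means these few. Any claim that something is new, unique, unknown or untested is made for them only; others in the source may bear on it.

Measured compounds:
Compound 1 `CC1CCN(c2nc(C(F)(F)F)ccc2CNC(=O)C(c2ccc(F)cc2)c2ccc(NS(C)(=O)=O)c(F)c2)CC1` — 3.4 nM
Compound 2 `CS(=O)(=O)Nc1ccc(C(C(=O)NCc2ccc(C(F)(F)F)nc2SC2CCCCC2)c2ccc(F)cc2)cc1F` — 37.6 nM
Compound 3 `Cc1ccc(C(C(=O)NCc2ccc(C(F)(F)F)nc2N2CCC(C)CC2)c2ccc(NS(C)(=O)=O)c(F)c2)cc1` — 1.1 nM

Compound 2 stands at the highest number of the three in an assay on CHO cells for antagonist activity at transient receptor potential cation channel subfamily V member 1 (Homo sapiens), read by FLIPR; on this read-out higher numbers stand for weaker inhibition and lower numbers for stronger inhibition; the nearest is compound 1, at 3.4 nM, and the furthest is compound 3, at 1.1 nM. Two steps are recorded. The first, an 11-fold higher number from compound 1 to compound 2 (1.04 log units; beyond the scatter), puts cyclohexylsulfanyl in place of 4-methylpiperidin-1-yl on an aromatic carbon. The second, a 3.1-fold lower number from compound 1 to compound 3 (0.49 log units; beyond the scatter), puts methyl in place of fluoro on an aromatic carbon.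

Compound 4 `CS(=O)(=O)Nc1ccc(C(Cc2ccc(F)cc2)C(=O)NCc2ccc(C(F)(F)F)nc2SC2CCCCC2)cc1F` is not yet measured. It differs from compound 2 by 4-fluorobenzyl in place of 4-fluorophenyl on a saturated chain carbon bound to an aromatic carbon and a carbonyl carbon. Neither measured step concerns this carbon: both change substituents on aromatic carbons, while this change lengthens the link between the saturated chain carbon and the ring. Going by the values given here, no step bears on it, so the direction and size rest on no direct precedent. Compound 4 is expected to give a higher number than compound 2 in this assay, with the step estimated at a 4.0-fold higher number from compound 2 to compound 4 (0.60 log units; beyond the scatter). Compound 4 is estimated at 150 nM, within a range from 40 nM to 600 nM.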

Compound 4, inhibition constant: "active" (no number reported)
Compound 4 has no reported number here, so the estimate cannot be set against anything.
By their numbers in this assay, from the lowest: compound 3; then compound 1; then compound 2.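

Going by these compounds alone, compound 4 is reported only as "active" in this assay, without a number, so no step from compound 2 to compound 4 can be read. The compounds shown leave open how far 4-fluorobenzyl in place of 4-fluorophenyl on the saturated chain carbon shifts the inhibition constant. No evidence given here bears on this result.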